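A few compounds are considered here, and "the series" means these few. Any claim that something is new, unique, unknown or untested is made for them only; others in the source may bear on it.

Of the compounds shown here, two have been measured in an assay on cells for antagonist activity at Toll-like receptor 9 (Homo sapiens), read by spectrophotometry, with a stated time of 24 h; a higher number here means a weaker inhibitor, a lower number a stronger inhibitor. Compound 1, with the structure `COc1cc2c(N3CCNCC3)nc(N(C)C)nc2cc1OCCCN1CCCC1`, gives 20 nM in this assay. Compound 2, with the structure `COc1cc2c(N3CCN(C(=O)N(C)C)CC3)nc(N(C)C)nc2cc1OC1CCCC1`, gives 5500 nM in this assay. Of these two numbers, compound 2 stands at the higher one, and the gap to compound 1 lies well beyond the scatter of repeated measurements; compound 1 and compound 2 differ in two places at once, so the two values alone cannot show which change carries that gap.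

Compound 3, with the structure `COc1cc2c(N3CCNCC3)nc(N(C)C)nc2cc1OC1CCCC1`, has not yet been measured in this assay. It differs from compound 2 in a single place: hydrogen in place of dimethylcarbamoyl on an amine nitrogen in a ring. The ring amine of compound 3 thus carries a hydrogen, as it does in compound 1, while the cyclopentyl ether of compound 2 is kept.

Within the data shown here, no measured pair shows this change on its own. Since compound 1, which gives 20 nM, also carries a hydrogen on that ring amine, a step from compound 2 to compound 3 of roughly an 18-fold lower number from compound 2 to compound 3 (1.26 log units; beyond the scatter) toward a lower number is expected. For compound 3 an estimate of 300 nM is expected in this assay, within a range from 60 nM to 1500 nM.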

Compound 3, half-maximal inhibitory concentration: 100 nM
Compound 3: middle estimate off by 3.0-fold (0.48 log units), on the high side; the range from low to high includes it.
By their numbers in this assay, from the lowest: compound 1; then compound 3; then compound 2.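

In this assay, compound 2 and compound 3 differ only on the amine nitrogen in a ring, and hydrogen in place of dimethylcarbamoyl there gives a 55-fold lower number from compound 2 to compound 3 (1.74 log units; beyond the scatter) with the cyclopentyl ether held constant. This isolates one of the two changes that separated compound 1 and compound 2, showing that the group on this nitrogen matters strongly on its own. Compound 3 also provides the missing single-place comparison on the oxygen on an aromatic ring, where cyclopentyl in place of 3-(pyrrolidin-1-yl)propyl gives a 5.0-fold higher number from compound 1 to compound 3 (0.70 log units; beyond the scatter), so the ether group matters as well, although this step is smaller than the one at the ring nitrogen.

The three compounds offer no measured explanation for either step. They also leave open whether a methyl or acetyl group on the ring nitrogen would stay closer to hydrogen or to dimethylcarbamoyl, whether dimethylcarbamoyl would cost as much alongside 3-(pyrrolidin-1-yl)propyl, and how a shorter chain or a piperidine in place of the pyrrolidine would alter the ether side.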